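Sulfonyl hydroxamates against bone morphogenetic protein 1: side chain swap

The compounds below may be only part of what the source reports. "The series", "measured", "known", "first", "only" and "open" are said of these compounds alone.

Measured so far:
compound 1 `COc1ccc(S(=O)(=O)N(Cc2cc(C(F)(F)F)cc(C(F)(F)F)c2)[C@H](C)C(=O)NO)cc1` — 220 nM
compound 2 `COc1ccc(S(=O)(=O)N(CCn2cccc2)[C@H](C)C(=O)NO)cc1` — 170 nM
compound 3 `COc1ccc(S(=O)(=O)N(Cc2sc3scc(C)c3c2C)[C@H](C)C(=O)NO)cc1` — 60 nM

All three share one core, a sulfonamide nitrogen carrying a hydroxamic acid branch, and differ only in the group on that nitrogen. In an assay on isolated protein for inhibition of bone morphogenetic protein 1 (Homo sapiens) (on this read-out higher numbers stand for weaker inhibition and lower numbers for stronger inhibition), compound 2 gives 170 nM, the second highest of the three numbers. Its nearest neighbour is compound 1, whose value in this assay of 220 nM lies within the scatter, so no order between the two can be read. Compound 3, in this assay at 60 nM, sits beyond the scatter from compound 2, the only clear separation in the set.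

Compound 4 `COc1ccc(S(=O)(=O)N(Cc2ccc(Cl)c(Cl)c2)[C@H](C)C(=O)NO)cc1` has not yet been measured in this assay. It differs from compound 2 as follows: 3,4-dichlorophenyl in place of (1H-pyrrol-1-yl)methyl on a saturated chain carbon bound to a sulfonamide nitrogen. Among the measured compounds shown here, no comparable step between measured compounds exists; the closest reference is compound 1, also a substituted benzyl on the sulfonamide nitrogen, at 220 nM. Compound 4 is therefore expected to give a number in this assay near that of compound 2, with the step of a 1.1-fold lower number from compound 2 to compound 4 (0.05 log units; within the scatter) estimated to stay within the scatter. The estimate for compound 4 in this assay is 150 nM, expected between 60 nM and 400 nM.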

Compound 4, half-maximal inhibitory concentration: 120 nM
Beside the measured number, compound 4's estimate is 1.3-fold (0.10 log units) above it, and the stated range covers the measured number.
By their numbers in this assay, from the lowest: compounds 3, 4, 2 and 1 (each within the scatter of the next, the first and the last beyond it).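

In this assay the change from 2-(1H-pyrrol-1-yl)ethyl to 3,4-dichlorobenzyl gives a 1.4-fold lower number from compound 2 to compound 4 (0.15 log units; within the scatter), so this position on the sulfonamide nitrogen takes a carbon-only six-membered aromatic ring with two chlorines in place of the five-membered ring on its chain, with no readable separation. The hydrogen-bond acceptor of the leaving group is absent from the entering group, and the read-out does not separate the pair. No independent evidence bears on this result.

Still open, on these data alone, is whether a carboxylic acid or an amine on the phenyl ring of compound 4 would move the number beyond the scatter. Equally open, as far as these compounds go, is what a longer chain, 3,4-dichlorophenethyl in place of 3,4-dichlorobenzyl, would do at this position.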